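A few compounds are considered here, and "the series" means these few. Any claim that something is new, unique, unknown or untested is made for them only; others in the source may bear on it.

Of the compounds shown here, three have been measured in a physicochemical assay for solubility, read by HPLC, in phosphate buffer, with a stated time of 16 h, at pH 6.8; on this read-out lower numbers stand for lower solubility and higher numbers for higher solubility. Compound 1, `Cc1ccc([C@H](C)NC(=O)Cn2nnc3ccccc3c2=O)c(F)c1`, gives 4500 nM in this assay. Compound 2, `Cc1ccc([C@H](C)NC(=O)Cn2nnc3ccc(C)cc3c2=O)cc1`, gives 3100 nM, and compound 3, `Cc1ccc([C@H](C)NC(=O)Cn2nnc3ccc(C(F)(F)F)cc3c2=O)cc1`, gives 6600 nM. The difference between the core of compound 1 and that of compound 2 is not broken down here. Compound 2 and compound 3 differ in one place, (trifluoromethyl in place of methyl on an aromatic carbon), and this change made a 2.1-fold higher number from compound 2 to compound 3 (0.33 log units; beyond the scatter). Compound 1 stands near both of the others in this assay, and its gaps to compound 2 and to compound 3 are within the scatter of the measurement.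

Compound 4, `C[C@H](NC(=O)Cn1nnc2ccccc2c1=O)c1ccc(C(F)(F)F)cc1F`, has not yet been measured. It differs from compound 1 in one place, (trifluoromethyl in place of methyl on an aromatic carbon). Going by the values given here, this is the same kind of change as the one from compound 2 to compound 3, but not the same: there the aromatic carbon belonged to a six-membered aromatic ring of carbon only, part of a fused or bridged system of two rings, meta to a fused ring and para to a fused ring, whereas in compound 4 the ring is a six-membered aromatic ring of carbon only, and the carbon is meta to a fluoro group and para to a large group.

Among the compounds with values here, compound 4 is expected to show a step of a 1.8-fold higher number from compound 1 to compound 4 (0.25 log units; within the scatter) in this assay, because the same change made a 2.1-fold higher number from compound 2 to compound 3 (0.33 log units; beyond the scatter) in the only measured pair, while the different surroundings of the place leave room for a different outcome. For compound 4 a value of 8000 nM is estimated, with a range from 3500 nM to 18000 nM.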

Compound 4, solubility: 300 nM
Estimate against measurement, compound 4: 27-fold (1.43 log units) above, and the stated range ends above it.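

In this assay, trifluoromethyl in place of methyl on an aromatic carbon gave a 15-fold lower number from compound 1 to compound 4 (1.18 log units; beyond the scatter), whereas the same kind of change on the other aromatic carbon gave a 2.1-fold higher number from compound 2 to compound 3 (0.33 log units; beyond the scatter). Both steps lie beyond the scatter and run in opposite directions, so in this series the result of this change did not carry from one place and core to the other, and the sign of one step could not be read across to the other. This does not show a rule for the change at either place, since each place rests on a single pair, and nothing given here bears on why the two steps part ways.

The compounds shown leave open whether the large drop belongs to trifluoromethyl on this carbon, meta to a fluoro group and para to a large group, or would also appear with another group there, such as a nitrile, a methoxy group or an amine. They also leave open whether the same change would give a drop or a rise on further cores of this series.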